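This account rests on a few compounds, and the source may have more. Where it says the series, first, only, none or still open, it means among the compounds named here.

Measured so far:
Compound 1 `Cc1cn(/C=C/C=O)c(=O)[nH]c1=O` gives 100000 nM
Compound 2 `Nc1ccn(/C=C/C=O)c(=O)n1` gives > 100000 nM (a limit of the assay, not a number)
Compound 3 `Nc1nc(O)c2ncn(/C=C/C=O)c2n1` gives 50000 nM

All three compounds were tested in a functional assay on HeLa cells (Homo sapiens) for inhibition (a lower number here means a stronger inhibitor, a higher number a weaker inhibitor), and carry the same 2-formylethenyl group on different cores. Compound 1 gives 100000 nM, and compound 3 at 50000 nM lies within the scatter of it. Compound 2 gives > 100000 nM, which is a limit and not a number. Among the measured compounds shown here, compound 1 therefore stands among weak inhibitors, with only one true number to compare it with.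

The next compound, compound 4 `O=C/C=C/n1cc(F)c(=O)[nH]c1=O`, keeps the core of compound 1 and has fluoro in place of methyl on an aromatic carbon, meta to the 2-formylethenyl group: fluoro in place of methyl on an aromatic carbon. For the measured compounds named here, no measured pair differs in one place only, so the size of this step can only be judged from the narrow spread of the values so far. A modest move towards stronger inhibition in this assay is expected, though a result within the scatter would be no surprise. The estimated change is a 2.5-fold lower number from compound 1 to compound 4 (0.40 log units; beyond the scatter). For compound 4 the expected value is 40000 nM, with an estimated range from 12000 nM to 100000 nM.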

Compound 4, half-maximal inhibitory concentration: 90000 nM
Compound 4: middle estimate off by 2.3-fold (0.35 log units), on the low side, and the stated range covers the measured number.
By their numbers in this assay, from the lowest: compounds 3, 4 and 1 (each within the scatter of the next).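

In this assay, among the compounds shown here, the exchange of methyl for fluoro on an aromatic carbon, meta to the 2-formylethenyl group, gives the first step between two compounds that differ in one place only (a 1.1-fold lower number from compound 1 to compound 4 (0.05 log units; within the scatter)). At this position, methyl and fluoro therefore cannot be told apart in this assay, and compound 4 joins compound 1 among the weak inhibitors, with the two values within the scatter of each other. This single step is read in a narrow band of weak values, and compound 2 gives a limit, not a number: the limit of > 100000 nM in this assay, at which 1 of the 4 values shown sits.

What the compounds shown leave open is whether any other group at this position, such as chloro, trifluoromethyl, an amine or a longer chain, would give a step beyond the scatter. Also open, on these data alone, is how the number would respond on the core of compound 1 to a carboxylic acid in place of the 2-formylethenyl group, so the part that this group plays in the weak inhibition seen here cannot be judged from these compounds.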